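The compounds below may be only part of what the source reports. "The series", "measured", "known", "first", "only" and "open" are said of these compounds alone.

In a functional assay on MGC-803 cells (Homo sapiens) for inhibition, read by MTT assay, with a stated time of 72 h (a lower number here means a stronger inhibitor, a higher number a weaker inhibitor), compound 1 `C#CCSc1nc(N2CCN(C)CC2)c2ccncc2n1` gives only a limit, > 80000 nM, which is the limit of > 80000 nM in this assay, at which 1 of the 3 values shown sits. Compound 2 `C#CCSc1nc(N2CCN(CC)CC2)c2ccncc2n1` gives 70600 nM in this assay; the change from compound 1, (methyl in place of hydrogen on a saturated chain carbon bound to an amine nitrogen in a ring), brought an at least 1.1-fold lower number from compound 1 to compound 2 (0.05 log units; that floor lies within the scatter). Compound 3 `CCSc1nc(Nc2cccc(OC)c2)c2ccncc2n1` gives 590 nM in this assay; how its core differs from the core of compound 1 is not broken down here. Compound 4 `CCCSc1nc(Nc2cccc(OC)c2)c2ccncc2n1` differs from compound 3 by methyl in place of hydrogen on a saturated chain carbon, two bonds along the chain from a sulfur, the same kind of change as from compound 1 to compound 2, though not the same: there the carbon is bound to an amine nitrogen in a ring, here it is two bonds along the chain from a sulfur. The earlier step of an at least 1.1-fold lower number from compound 1 to compound 2 (0.05 log units; that floor lies within the scatter) stayed within the scatter, so the estimated step is a 1.2-fold lower number from compound 3 to compound 4 (0.07 log units; within the scatter). Compound 4 is expected to give 500 nM in this assay, between 200 nM and 1500 nM.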

Compound 4, half-maximal inhibitory concentration: 1950 nM
Beside the measured number, compound 4's estimate is 3.9-fold (0.59 log units) below it, and the stated range ends below it.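

In this assay the change from ethylsulfanyl to propylsulfanyl gave a 3.3-fold higher number from compound 3 to compound 4 (0.52 log units; beyond the scatter) and so weakened inhibition modestly on this core. The methyl in place of hydrogen therefore did not carry over as one fixed step between the two cores: the same change on two cores in this assay, an at least 1.1-fold lower number (0.05 log units; that floor lies within the scatter) from compound 1 to compound 2 and a 3.3-fold higher number (0.52 log units; beyond the scatter) from compound 3 to compound 4, at least 3.7-fold (0.57 log units) apart, beyond the scatter of two such steps. Compound 1 gives > 80000 nM as a limit and not a number, and the methyl sits at a different place on each core, so the data do not show the true size of the earlier step, nor whether the core or the place of the methyl decides the difference.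

The compounds shown leave open whether a butyl chain on the sulfur would extend the loss seen with propylsulfanyl. They also leave open how an amine at the end of that chain would read.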